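The source may hold more compounds than are shown below. What is called first, only, known or untested is meant among the compounds shown, and "the series" means these compounds.

Compounds measured so far in an ADME assay on Vero cells (Chlorocebus sabaeus) for cytotoxicity; on this read-out higher numbers stand for lower toxicity in this test and lower numbers for higher toxicity in this test:

Compound 1 `O=C(CN1CCCCC1)Nc1ccc(-c2nc3cc(Cl)c(Cl)cc3[nH]2)cc1` — in this assay compound 1 gives > 100000 nM, which is a limit of the assay and not a number.
Compound 2 `O=[N+]([O-])c1ccc(-c2nc3cc(Cl)c(Cl)cc3[nH]2)cc1` — in this assay compound 2 gives >= 100000 nM, again a limit rather than a number.
Compound 3 `Nc1ccc(-c2nc3cc(Cl)c(Cl)cc3[nH]2)cc1` — in this assay compound 3 gives >= 100000 nM, also a limit and not a number.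

Compound 3 therefore stands where the other two stand: at the limit of this assay, with no number of its own. Both measured steps lead into compound 3. The step that the two limits leave unreadable from compound 1 to compound 3 cannot be read in size due to the limit of > 100000 nM in this assay, at which 1 of the 3 values shown sits, and (the limit of >= 100000 nM in this assay, at which 2 of the 3 values shown sit). The step that the two limits leave unreadable from compound 2 to compound 3 is likewise unreadable due to the limit of >= 100000 nM in this assay, at which 2 of the 3 values shown sit. Neither step therefore shows a direction or a size that could be carried forward.

The next compound, compound 4 `Oc1ccc(-c2nc3cc(Cl)c(Cl)cc3[nH]2)cc1`, differs from compound 3 in one place: hydroxy in place of amino on an aromatic carbon. The change swaps one single heavy atom for another on the same aromatic carbon, with the count of donors and acceptors unchanged. Within the data shown here, no measured step bears readably on this change, so no step beyond the scatter is expected in this assay, in either direction; the expected step of a number no higher from compound 3 to compound 4 (the limit leaves the size open) is taken as flat. Compound 4 is accordingly estimated at 100000 nM, within 50000 nM to 200000 nM, most likely reported once more as a limit only.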

Compound 4, half-maximal cytotoxic concentration: 18000 nM
Estimate against measurement, compound 4: 5.6-fold (0.74 log units) above, and the stated range ends above it.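

Among these compounds, this position, para to a large group, gives the first readable change in this assay, where the earlier steps could not be read: hydroxy in place of amino gives an at least 5.5-fold lower number from compound 3 to compound 4 (0.74 log units; beyond the scatter), and hydroxy in place of nitro gives an at least 5.5-fold lower number from compound 2 to compound 4 (0.74 log units; beyond the scatter). The amino and hydroxy groups match in the counts of heavy atoms, donors and acceptors, yet the read-out still moves beyond the scatter, and compound 4 is the only compound shown with a number rather than a limit. Both steps give only a minimum size, because their starting compounds sit at a limit: the limit of >= 100000 nM in this assay, at which 2 of the 4 values shown sit.

The compounds shown do not tell whether the lower number depends on the hydrogen of the hydroxy group, a point that a methoxy group at this position would address. On these data alone, how a carboxylic acid, or a longer chain ending in a hydroxy group, would stand at this position in this assay also remains open.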